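Aryl urea exchange on a shared core in KM12 cells

A few compounds are considered here, and "the series" means these few. Any claim that something is new, unique, unknown or untested is made for them only; others in the source may bear on it.

compound 1, `COc1cc2cc(Oc3ccc(NC(=O)Nc4ccc(C)cc4)cc3)c(C)nc2cc1OC`: 104%
compound 2, `COc1cc2cc(Oc3ccc(NC(=O)Nc4cccc(C(F)(F)F)c4)cc3)c(C)nc2cc1OC`: -10.2%
compound 3, `COc1cc2cc(Oc3ccc(NC(=O)Nc4ccc(Cl)c(Cl)c4)cc3)c(C)nc2cc1OC`: not yet measured

In a functional assay on KM12 cells (Homo sapiens) for inhibition, read by sulforhodamine B assay, with a stated time of 48 h, tested at 10 uM (a lower number here means a stronger effect, a higher number a weaker effect of the compound at the concentration tested), compound 1 gives 104% and compound 2 gives -10.2%. Among the compounds with values here, compound 2 stands lowest of the two numbers measured; its only neighbour is compound 1, and the single step measured so far, a number 114.2 percentage points lower from compound 1 to compound 2 (beyond the scatter), is large and well beyond the scatter. The next step, from compound 2 to compound 3, is 3,4-dichlorophenyl in place of 3-(trifluoromethyl)phenyl on an amide-type nitrogen. Within the data shown here, no measured step covers this particular exchange; the step of a number 114.2 percentage points lower from compound 1 to compound 2 (beyond the scatter) only shows that the aryl group on the amide-type nitrogen can move the read-out across nearly its whole range, so it sets the scale of what is possible without fixing the direction. Since compound 2 already sits at the bottom of the observed range, the step of a number 18.2 percentage points higher from compound 2 to compound 3 (beyond the scatter) is expected to be modest and most likely upward, though a result within the scatter is also plausible. Compound 3 is therefore estimated at 8%, with a range from -20% to 55%.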

Compound 3, a percentage reported as activity, at one concentration (the size of the read-out at that concentration, not a potency): 13.9%
Compound 3: the middle estimate sits 5.9 percentage points below what was measured; measured number inside the range.
By their numbers in this assay, from the lowest: compound 2; then compound 3; then compound 1.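

In this assay the exchange of 3-(trifluoromethyl)phenyl for 3,4-dichlorophenyl on the amide-type nitrogen gives a number 24.1 percentage points higher from compound 2 to compound 3 (beyond the scatter), so this position still separates two aryl groups that both lie far from compound 1 and the low read-out is not confined to the trifluoromethyl group. The other comparison, a number 90.1 percentage points lower from compound 1 to compound 3 (beyond the scatter), shows that a second replacement of 4-methylphenyl also produces a large drop, and among the three compounds the two aryl groups carrying halogen atoms read low while compound 1, with its methyl group and no halogen, goes against them by standing high. Nothing available bears on the reason for either step.

Each read-out comes from a single concentration, so the order of the three compounds says nothing firm about their potencies. As far as these compounds go, it remains open whether a single chlorine, a methoxy group or a dimethylamino group on the same phenyl ring would keep the read-out near that of compound 2 or return it towards that of compound 1.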